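Fluoro for Methyl, Repeated on a Second Core

The source may hold more compounds than are shown below. What is called first, only, known or untested is meant among the compounds shown, and "the series" means these compounds.

Compound 1 `Cc1ccc(-n2nc(C(=O)Nc3ccc(Oc4ncnc5ccsc45)c(F)c3)c(C)cc2=O)cc1` and compound 2 `Cc1cc(=O)n(-c2ccc(F)cc2)nc1C(=O)Nc1ccc(Oc2ncnc3ccsc23)c(F)c1` share one core, while compound 3 `Cc1ccc(-n2nc(C(=O)Nc3ccc(Oc4ncnc5sccc45)c(F)c3)c(C)cc2=O)cc1` and compound 4 `Cc1cc(=O)n(-c2ccc(F)cc2)nc1C(=O)Nc1ccc(Oc2ncnc3sccc23)c(F)c1` share a second one. In a functional assay on MCF7 cells (Homo sapiens) for cytotoxicity, read by MTT assay, with a stated time of 72 h (on this read-out lower numbers stand for stronger inhibition and higher numbers for weaker inhibition), compound 1 gives 7250 nM, and compound 2 gives 740 nM. The change between these two, (fluoro in place of methyl on an aromatic carbon), produced a 9.8-fold lower number from compound 1 to compound 2 (0.99 log units; beyond the scatter).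

Compound 3 differs from compound 1 by a group of 9 heavy atoms (6 carbon, 2 nitrogen, 1 sulfur; one five-membered aromatic ring with 1 hetero atom, one six-membered aromatic ring with 2 hetero atoms) in place of a group of 9 heavy atoms (6 carbon, 2 nitrogen, 1 sulfur; one five-membered aromatic ring with 1 hetero atom, one six-membered aromatic ring with 2 hetero atoms), on an oxygen on an aromatic ring. In this assay compound 3 reaches only a limit of the assay, > 40000 nM. The comparison with compound 1 therefore reads as an at least 5.5-fold higher number from compound 1 to compound 3 (0.74 log units; beyond the scatter), and one of the three measured values sits at the limit of > 40000 nM in this assay, at which 1 of the 3 values shown sits.

Compound 4 carries, relative to compound 3, the change (fluoro in place of methyl on an aromatic carbon). The place of this change is the same as on the first core, so it is the same change, now made on a core that starts from a limit rather than a number. Because the starting point of compound 3 is only a limit > 40000 nM, the expected number for compound 4 cannot be pinned down closely, and the estimate is kept wide. Compound 4 is expected to give about 8000 nM in this assay, with a likely range from 2500 nM to 40000 nM. That estimate corresponds to an expected at least 5.0-fold lower number from compound 3 to compound 4 (0.69 log units; beyond the scatter), which rests on the earlier step of a 9.8-fold lower number from compound 1 to compound 2 (0.99 log units; beyond the scatter) measured on the first core, and carries a real chance that the assay again reports only a limit.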

Compound 4, half-maximal inhibitory concentration: 12300 nM
For compound 4 the middle estimate is 1.5-fold (0.19 log units) below the measured one; the range from low to high includes it.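

On the second core, the move from 4-methylphenyl to 4-fluorophenyl gives an at least 3.2-fold lower number from compound 3 to compound 4 (0.51 log units; beyond the scatter) in this assay, which runs in the same direction as on the first core: the same change on two cores in this assay, a 9.8-fold lower number (0.99 log units; beyond the scatter) from compound 1 to compound 2 and an at least 3.2-fold lower number (0.51 log units; beyond the scatter) from compound 3 to compound 4; the limit leaves it open whether they differ. Compound 3 stands only at a limit of the assay, > 40000 nM, so these compounds show that the direction of the change carried over, but not whether its size did. The change of core, read with the fluoro group in place, gives a 17-fold higher number from compound 2 to compound 4 (1.22 log units; beyond the scatter), which runs the same way as the step from compound 1 to compound 3, and here too the size of the effect cannot be compared: the same change on two cores in this assay, an at least 5.5-fold higher number (0.74 log units; beyond the scatter) from compound 1 to compound 3 and a 17-fold higher number (1.22 log units; beyond the scatter) from compound 2 to compound 4; the limit leaves it open whether they differ.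

The compounds shown carry only methyl or fluoro at this place, so they leave open whether chloro or methoxy there would also lower the number on both cores. They also leave open whether an amine or a carboxylic acid at the same place would keep the core of compound 2 ahead of the core of compound 4, or whether that gap depends on the group chosen.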